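The compounds below may be only part of what the source reports. "The series", "measured", "known", "first", "only" and "open" are said of these compounds alone.

Measured compounds in an ADME assay on microsomes from liver (Rattus norvegicus) for metabolic stability; on this read-out higher numbers stand for a longer-lived compound and lower numbers for a shorter-lived compound:
- compound 1 `CC(C)C(c1nnc[nH]1)c1ccc(-c2ccc3cccc(F)c3c2)[nH]c1=O`: 0.552 h
- compound 2 `CC(C)C(c1ccc(-c2ccc3cccc(F)c3c2)[nH]c1=O)N1CCCCC1=O`: 0.102 h
- compound 3 `CC(C)C(/C=C1\CCNC1=O)c1ccc(-c2ccc3cccc(F)c3c2)[nH]c1=O`: 0.345 h

Compound 3 is the second highest of these three numbers. Its nearest neighbour is compound 1, and the gap between them, a 1.6-fold lower number from compound 1 to compound 3 (0.20 log units; within the scatter), is within the scatter, so the two cannot be told apart. Its furthest neighbour is compound 2, reached through a 3.4-fold higher number from compound 2 to compound 3 (0.53 log units; beyond the scatter).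

The next compound, compound 4 `CC(C)C(Cc1nnn[nH]1)c1ccc(-c2ccc3cccc(F)c3c2)[nH]c1=O`, carries the change (a group of 6 heavy atoms (2 carbon, 4 nitrogen; one five-membered aromatic ring with 4 hetero atoms) in place of a group of 7 heavy atoms (5 carbon, 1 nitrogen, 1 oxygen; one five-membered non-aromatic ring with 1 hetero atom), on a saturated chain carbon bound to an aromatic carbon and a saturated chain carbon). Two of the measured steps speak to this. The step from compound 1 to compound 3 exchanged a five-membered aromatic ring with three hetero atoms for the non-aromatic group now leaving, and it stayed within the scatter. The step from compound 2 to compound 3, where a six-membered non-aromatic ring gave way to the same non-aromatic group, was modest. Since compound 4 brings back a five-membered aromatic ring, this time with four hetero atoms and a one-carbon link, the nearest guide is compound 1 at 0.552 h, and the step to compound 4 is expected to stay near or within the scatter, leaning slightly upward: a 1.4-fold higher number from compound 3 to compound 4 (0.16 log units; within the scatter). Compound 4 is therefore estimated at 0.5 h in this assay, within a range from 0.25 h to 1 h.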

Compound 4, half-life: 2.08 h
The estimate for compound 4 lay 4.2-fold (0.62 log units) below the measured number; measured number above the stated range.
By their numbers in this assay, from the lowest: compound 2; then compounds 3 and 1 (each within the scatter of the next); then compound 4.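

At this position, a saturated chain carbon bound to an aromatic carbon and a saturated chain carbon, (1H-tetrazol-5-yl)methyl gives the highest number of the four compounds in this assay, clear of each of the others (a 6.0-fold higher number from compound 3 to compound 4 (0.78 log units; beyond the scatter); a 3.8-fold higher number from compound 1 to compound 4 (0.58 log units; beyond the scatter); a 20-fold higher number from compound 2 to compound 4 (1.31 log units; beyond the scatter)). A five-membered aromatic ring alone does not settle the outcome here: compound 1 also carries one, yet it stays within the scatter of compound 3, which has a non-aromatic ring, while compound 4 stands apart from both. No measurement shown here explains why this group gives the higher number.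

Compound 4 differs from compound 1 both in its ring and in its methyl link, so the compounds shown cannot say which of the two carries the rise. A 1H-tetrazol-5-yl group set directly on the chain carbon, or a (4H-1,2,4-triazol-3-yl)methyl group, would pull the two apart, and a carboxymethyl group would test whether the same link with no ring at its end behaves alike.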